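From compound 2 to compound 3: a fluoro step

The source may report more compounds than this note shows. Statements on the series, on what has been measured and on what is new or still open speak of the compounds shown alone.

In a functional assay on HT-29 cells (Homo sapiens) for antiproliferative activity, read by sulforhodamine B assay, with a stated time of 72 h (a lower number here means a stronger inhibitor, a higher number a weaker inhibitor), compound 1 (`O=C(Cn1nc(-c2ccccc2)c2ccccc2c1=O)Nc1ccccc1`) gives 99000 nM as its value, and compound 2 (`O=C(Cn1nc(Cc2ccccc2)c2ccccc2c1=O)Nc1ccccc1`) gives 95400 nM as its value. Benzyl in place of phenyl on an aromatic carbon amounts to a 1.0-fold lower number from compound 1 to compound 2 (0.02 log units; within the scatter) so compound 2 stands level with compound 1, and the two cannot be ranked.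

Compound 3 (`O=C(Cn1nc(Cc2ccccc2)c2ccccc2c1=O)Nc1ccc(F)cc1`) differs from compound 2 by fluoro in place of hydrogen on an aromatic carbon so that anilino becomes (4-fluorophenyl)amino. Within the data shown here, no measured step covers a change at this place. Among the measured compounds shown here, the only step available, from compound 1 to compound 2, lies elsewhere in the molecule and bears on the question only indirectly. Its size, a 1.0-fold lower number from compound 1 to compound 2 (0.02 log units; within the scatter) gives no sign of a sharp response in this series, though it rests on a single pair.

The expected change is a 1.1-fold lower number from compound 2 to compound 3 (0.05 log units; within the scatter) and no step beyond the scatter is expected in either direction. For compound 3 the estimate is 85000 nM (expected range 35000 nM to 170000 nM).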

Compound 3, half-maximal inhibitory concentration: 98000 nM
Estimate against measurement, compound 3: 1.2-fold (0.06 log units) below; low and high end bracket the measured number.
By their numbers in this assay, from the lowest: compounds 2, 3 and 1 (each within the scatter of the next).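

Fluoro in place of hydrogen on an aromatic carbon, para to a large group, gives the series its first reading at the anilino end, and in this assay it amounts to a 1.0-fold higher number from compound 2 to compound 3 (0.01 log units; within the scatter) and leaves compound 2 and compound 3 unranked. The earlier pair, at a 1.0-fold lower number from compound 1 to compound 2 (0.02 log units; within the scatter) for benzyl in place of phenyl, spoke only for the other end of the molecule, so two separate places have now been changed in one step each, and neither step lies beyond the scatter. No measurement at hand accounts for this flat response.

The compounds shown leave open whether this place responds at all, since a single fluorine is one small change, and a carboxylic acid, a primary amine or a methoxy group on the same ring could read differently. On these data alone, it is also open whether a longer chain such as phenethyl in place of benzyl would give a step beyond the scatter, and whether any change at either place would move these compounds away from the level of compound 3 at 98000 nM in this assay.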